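The compounds below may be only part of what the source reports. "The series", "measured", "known", "first", "only" and "open" are said of these compounds alone.

Compound 1 `NC(C(=O)NCC(=O)Nc1ccc(Cl)cc1C(=O)c1ccccc1)c1ccccc1`, compound 2 `CN(C(=O)CNC(=O)CN)c1ccc(Cl)cc1C(=O)c1ccccc1Cl` and compound 3 `CCC(=O)NCC(=O)N(C)c1ccc(Cl)cc1C(=O)c1ccccc1Cl` share one core and were tested in a functional assay on the whole organism with Mus musculus as the target, in the rotarod test; a higher number here means that more compound is needed for the effect, a lower number that less compound is needed. For compound 1 the result is only a limit of the assay, > 100 mg/kg, not a number. Compound 2 gives 27.7 mg/kg and compound 3 gives 36 mg/kg. Of the two numbers compound 2 stands lowest, with compound 3 nearest; the gap is within the scatter, so the two cannot be ordered. Compound 4 `CN(C(=O)CNC(=O)c1ccccc1)c1ccc(Cl)cc1C(=O)c1ccccc1Cl` has not been measured in this assay. It differs from compound 2 by phenyl in place of aminomethyl on a carbonyl carbon. For the measured compounds named here, the only measured step that touches the same end of the chain, a 1.3-fold higher number from compound 2 to compound 3 (0.11 log units; within the scatter), exchanged the amino for a methyl and left the number within the scatter. Going by the values given here, the exchange for phenyl is larger, and no measured pair shows it directly. A step no larger than the scatter, if anything toward a higher number, is therefore expected, a 1.6-fold higher number from compound 2 to compound 4 (0.21 log units; within the scatter). For compound 4 the estimate is 45 mg/kg, with a range from 20 mg/kg to 100 mg/kg.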

Compound 4, dose for half-maximal effect: > 100 mg/kg
Compound 4: only a limit was reported; the forecaster's own chance of this, stated with the estimate: 25%; middle value at least 2.2-fold (0.34 log units) from the limit.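

At the carbonyl carbon, this end of the chain now shows a clear response in this assay, which the exchange of amino for methyl did not show: phenyl in place of aminomethyl gives an at least 3.6-fold higher number from compound 2 to compound 4 (0.55 log units; beyond the scatter), and phenyl in place of ethyl gives an at least 2.7-fold higher number from compound 3 to compound 4 (0.44 log units; beyond the scatter). Compound 3 also lacks the amino group, so the shift goes with the entry of phenyl and not with the loss of the amino group alone. The value of compound 4 is a limit of the assay and not a number, so both steps have a lower bound only: the limit of > 100 mg/kg in this assay, at which 2 of the 4 values shown sit.

From the compounds shown here alone, it remains open whether a cyclohexyl ring, a benzyl group or a longer chain such as butyl on this carbonyl carbon would behave like phenyl or like ethyl. Going by these compounds, it also remains open whether a substituted phenyl, such as an aminophenyl, would bring the number back within the range of the measured values.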